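A Single Stereocentre Flip in a Very Weak Series

This account rests on a few compounds, and the source may have more. Where it says the series, first, only, none or still open, it means among the compounds named here.

Compound 1 `CCCCCCC[C@H]1OC2=C(C(=O)O[C@@]2(C)O)[C@@H](O)[C@]1(C)O` returned > 100000 nM in a functional assay on HeLa cells (Homo sapiens) for cytotoxicity, read by MTT assay (a higher number here means a weaker inhibitor, a lower number a stronger inhibitor), and that reading is a limit of the assay, not a number. Within the data shown here, compound 2 `CCCCCCC[C@H]1OC2=C(C(=O)O[C@@H]2C)[C@@H](O)[C@]1(C)O` gives 100000 nM in this assay as the only true number so far, which marks very weak cytotoxicity. Compound 3 `CCCCCCC[C@H]1OC2=C(C(=O)O[C@@H]2C)[C@@H](O)[C@@]1(C)O` has not yet been measured, and the change from compound 2 is small (the two compounds have the same atoms and bonds and differ only in configuration as drawn: 1 of 4 stereo elements differ; a stereocentre at a saturated ring carbon is drawn S in compound 2 and R in compound 3). Among the measured compounds shown here, no measured pair shows what such a flip does, so the expectation rests on compound 2 at 100000 nM alone. The expected change is no change at the digits printed from compound 2 to compound 3 (within the scatter) with no favoured direction and nothing beyond the usual scatter. A result reported only as a limit would be no surprise. Compound 3 is estimated at 100000 nM with an expected range from 50000 nM to 200000 nM for this measurement.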

Compound 3, half-maximal inhibitory concentration: > 100000 nM
Compound 3: a limit, no number (the forecaster's own chance of this, stated with the estimate: 50%); the middle value sits exactly at the limit.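

Drawing this saturated ring carbon as R instead of S gives a number no lower from compound 2 to compound 3 (the limit leaves the size open), so the flip brings no gain in potency in this assay. Among these compounds, this is the first step that can be tied to a single stereocentre, and the link is direct for one reason: the fact that compounds 2 and 3 differ only in the configuration as drawn. How much the flip weakens the compound, if at all, cannot be read for one reason: the limit of > 100000 nM in this assay, at which 2 of the 3 values shown sit.

The compounds shown leave open whether an amine or a carboxylic acid on the shared core would give a true number well clear of the limit. They also leave open what flipping any of the other stereocentres would do.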